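Series notes: the step from compound 3 to compound 4

This account rests on a few compounds, and the source may have more. Where it says the series, first, only, none or still open, it means among the compounds named here.

Measured so far in this series:
Compound 1, `CCOc1ccccc1-n1nncc1CN1C(=O)C2(C(C#N)=C(N)Oc3c2c2nc4ccccc4nc2c2ccccc32)c2ccccc21`: in a functional assay on A549 cells (Homo sapiens) for antiproliferative activity, read by MTT assay, with a stated time of 48 h (a higher number here means a weaker inhibitor, a lower number a stronger inhibitor), compound 1 returns only a limit, > 50000 nM.
Compound 2, `N#CC1=C(N)Oc2c(c3nc4ccccc4nc3c3ccccc23)C12C(=O)N(Cc1cnnn1-c1cc(Cl)ccc1Cl)c1ccccc12`: in this assay compound 2 also returns only a limit, > 50000 nM.
Compound 3, `N#CC1=C(N)Oc2c(N)cc3nc4ccccc4nc3c2C12C(=O)N(Cc1cnnn1-c1ccccc1Br)c1ccccc12`: in this assay compound 3 gives 27400 nM.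

Within the data shown here, compound 3 thus stands as the only measured number; the other two entries sit at the limit of > 50000 nM in this assay, at which 2 of the 3 values shown sit. Among the measured compounds shown here, the single one-point step available, a step that the two limits leave unreadable from compound 1 to compound 2, runs between two limits and its size cannot be read.

Compound 4, `COc1cc(-n2nncc2CN2C(=O)C3(C(C#N)=C(N)Oc4c(N)cc5nc6ccccc6nc5c43)c3ccccc32)c(OC)cc1Cl`, differs from compound 3 by 4-chloro-2,5-dimethoxyphenyl in place of 2-bromophenyl on an aromatic nitrogen. For the measured compounds named here, no measured step bears readably on a change of this kind at this position, and the one step between compound 1 and compound 2 gives no size to carry over. The expected step from compound 3 to compound 4 is therefore none beyond the scatter, a 1.1-fold higher number from compound 3 to compound 4 (0.04 log units; within the scatter). For compound 4 the expected value in this assay is 30000 nM, with a range from 10000 nM to 90000 nM, and a fair chance that only a limit is returned.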

Compound 4, half-maximal inhibitory concentration: > 50000 nM
Compound 4 ended at the assay's limit (the forecaster's own chance of this, stated with the estimate: 40%); middle value at least 1.6-fold (0.22 log units) away from the limit.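

In this assay, among these compounds, 4-chloro-2,5-dimethoxyphenyl in place of 2-bromophenyl on the aromatic nitrogen gives an at least 1.8-fold higher number from compound 3 to compound 4 (0.26 log units; that floor lies within the scatter), the first step at this position with a readable floor. Compound 4 returns > 50000 nM, which is a limit of the assay and not a number. No gain appears from this change, although the floor alone does not establish a real loss, and compound 3 still holds the only measured number in a series otherwise at one ceiling: the limit of > 50000 nM in this assay, at which 3 of the 4 values shown sit.

Going by these compounds, how far compound 4 really lies from compound 3 stays open, as the step has a floor and no size. Also open, on these data alone, is whether an n-butyl chain or a phenyl ring bearing a carboxylic acid at this position would move the value away from that of compound 3.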